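From 5-Chlorothiophen-2-yl to 3-Hydroxyphenyl on the Sulfonyl Sulfur

The source may report more compounds than this note shows. Statements on the series, on what has been measured and on what is new or still open speak of the compounds shown alone.

Of the compounds shown here, three have been read in an ADME assay on HEK293 cells (Homo sapiens) for cytotoxicity, read by resazurin assay, with a stated time of 48 h (on this read-out higher numbers stand for lower toxicity in this test and lower numbers for higher toxicity in this test), so far. Compound 1 (`O=S(=O)(Nc1ccc2oc(-c3ccccc3)nc2c1)c1cccc(C(F)(F)F)c1`) gives > 100000 nM here, which is a limit of the assay and not a number. Compound 2 (`Cc1ccc(S(=O)(=O)Nc2ccc(-c3nc4ccccc4o3)cc2)cc1`) gives a measured 88000 nM in the same test. Compound 3 (`O=S(=O)(Nc1ccc(-c2nc3ccccc3o2)cc1)c1ccc(Cl)s1`) gives > 100000 nM here, again only a limit. Compound 3 therefore stands at the limit of > 100000 nM in this assay, at which 2 of the 3 values shown sit, and has no exact value to start from.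

The next compound, compound 4 (`O=S(=O)(Nc1ccc(-c2nc3ccccc3o2)cc1)c1cccc(O)c1`), carries 3-hydroxyphenyl in place of 5-chlorothiophen-2-yl on a sulfonyl sulfur. One measured change at this place bears on it, 5-chlorothiophen-2-yl in place of 4-methylphenyl, and it amounts to an at least 1.1-fold higher number from compound 2 to compound 3 (0.05 log units; that floor lies within the scatter) in this assay as its only known size. The expectation also rests on compound 2, which has 4-methylphenyl on that sulfur and reads 88000 nM in the same test.

No step beyond the scatter is therefore expected, and the estimated change is an at least 1.1-fold lower number from compound 3 to compound 4 (0.07 log units; that floor lies within the scatter) at most a slight move towards lower numbers. Compound 4 is estimated at 85000 nM in this assay, with an expected range from 35000 nM to 100000 nM and a fair chance of another reading at the limit.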

Compound 4, half-maximal cytotoxic concentration: > 100000 nM
Compound 4: a limit, no number (the forecaster's own chance of this, stated with the estimate: 45%); middle value at least 1.1-fold (0.07 log units) from the limit.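

With 3-hydroxyphenyl on the sulfonyl sulfur, which brings a hydrogen-bond donor that 5-chlorothiophen-2-yl lacks, compound 4 in this assay gives > 100000 nM, and this is a limit of the assay and not a number. Compound 3 also reads as a limit, so the step between these two compounds cannot be read, and nothing separates a six-membered carbon ring carrying a hydroxyl from the chlorinated five-membered ring. Set against 4-methylphenyl, the new group gives an at least 1.1-fold higher number from compound 2 to compound 4 (0.05 log units; that floor lies within the scatter), so no step shown at this place can yet be read as beyond the scatter, and the test has little room left to separate such groups: the limit of > 100000 nM in this assay, at which 3 of the 4 values shown sit.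

Among the compounds shown here, what remains open is whether any group on this sulfonyl sulfur would bring the reading clearly under that of compound 2, which gives 88000 nM as the only exact value so far. A chain ending in an amine, or a phenyl ring carrying a carboxylic acid, would be a different kind of group from the three aromatic ones shown here, and how either would read in this assay is unknown.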